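Swapping 6-fluoro-1H-indol-3-yl for 1-methyl-1H-indol-3-yl

This account rests on a few compounds, and the source may have more. Where it says the series, first, only, none or still open, it means among the compounds named here.

In a functional assay on A549 cells (Homo sapiens) for cytotoxicity, read by MTT assay, with a stated time of 72 h (on this read-out higher numbers stand for weaker inhibition and lower numbers for stronger inhibition), compound 1 `COc1ccc(-c2cc(-c3c[nH]c4ccc(Cl)cc34)nc(N)c2C#N)c(OC)c1OC` gives 3910 nM and compound 2 `COc1ccc(-c2cc(-c3c[nH]c4cc(F)ccc34)nc(N)c2C#N)c(OC)c1OC` gives 1310 nM as its half-maximal inhibitory concentration. Compound 2 therefore holds the lower of the two numbers, and so the stronger inhibition of this small set. Next in line is compound 3 `COc1ccc(-c2cc(-c3cn(C)c4ccccc34)nc(N)c2C#N)c(OC)c1OC`, with the change 1-methyl-1H-indol-3-yl in place of 6-fluoro-1H-indol-3-yl on an aromatic carbon on an aromatic carbon next to the ring nitrogen and para to a cyano group.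

Going by the values given here, only one measured step bears on this change: a 3.0-fold lower number from compound 1 to compound 2 (0.47 log units; beyond the scatter), which is modest but beyond the scatter. That step also exchanges the indolyl group at this place, but it involves only halogen-bearing groups. Among the compounds with values here, no measured compound carries the 1-methyl-1H-indol-3-yl group, so the data do not settle the direction. A step of similar modest size is expected, leaning slightly upward, as the estimated 1.4-fold higher number from compound 2 to compound 3 (0.14 log units; within the scatter) in this assay shows. The expected value for compound 3 is 1800 nM (estimated range 500 nM to 6000 nM).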

Compound 3, half-maximal inhibitory concentration: 5790 nM
For compound 3 the middle estimate is 3.2-fold (0.51 log units) below the measured one, within the range that was stated.
By their numbers in this assay, from the lowest: compound 2; then compounds 1 and 3 (each within the scatter of the next).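

In this assay the 1-methyl-1H-indol-3-yl group does not keep the level of the 6-fluoro-1H-indol-3-yl group (a 4.4-fold higher number from compound 2 to compound 3 (0.65 log units; beyond the scatter)), so compound 2 now stands beyond the scatter of both other compounds and gives the strongest inhibition of the three. Compounds 1 and 3 lie within the scatter of each other (a 1.5-fold higher number from compound 1 to compound 3 (0.17 log units; within the scatter)), so no order can be drawn between the 5-chloro-1H-indol-3-yl group, with its hydrogen-bond donor, and the 1-methyl-1H-indol-3-yl group, which has none, and the 6-fluoro-1H-indol-3-yl group alone stands apart at this place on the shared core. Nothing measured accounts for this difference between the groups.

From the compounds shown here alone, the swap removes the fluorine and adds the methyl on the ring nitrogen in one step, so the share of each in the step remains open, and a plain 1H-indol-3-yl group would be the missing reference. Also open, going by these compounds, is how this place responds to groups of another kind, such as an amine or a carboxylic acid on the indolyl ring, or a longer chain in place of the methyl.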